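The compounds below may be only part of what the source reports. "The series", "measured", "known", "first", "only" and "open" are said of these compounds alone.

Measured so far in an assay on isolated protein for inhibition of CD40-CD40L (Homo sapiens), read by ELISA, with a stated time of 1 h; on this read-out higher numbers stand for weaker inhibition and lower numbers for stronger inhibition:
- compound 1 `O=C(Nc1ccc(-c2ccc(C(=O)Nc3ccc(C(=O)O)c4ccccc34)cc2)cc1)c1ccc([N+](=O)[O-])cc1`: 360 nM
- compound 2 `COC(=O)c1ccc(C(=O)Nc2ccc(-c3ccc(C(=O)Nc4cccc5cccc(S(=O)(=O)O)c45)cc3)cc2)cc1`: 170 nM
- compound 3 `O=C(Nc1ccc(-c2ccc(C(=O)Nc3cccc4cccc(S(=O)(=O)O)c34)cc2)cc1)c1ccc([N+](=O)[O-])cc1`: 310 nM

Compound 3 sits second highest of the three numbers. Its nearest neighbour is compound 1, whose 360 nM lies within the scatter of compound 3, so the two are not separated. Against compound 2 the single one-place step runs a 1.8-fold higher number from compound 2 to compound 3 (0.26 log units; within the scatter), again within the scatter, so nitro and methoxycarbonyl on the aromatic carbon of the terminal amide substituent are not distinguished here.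

Compound 4 `O=C(Nc1ccc(-c2ccc(C(=O)Nc3cccc4cccc(S(=O)(=O)O)c34)cc2)cc1)c1ccc2[nH]nnc2c1` is the next one-place step from compound 3: a group of 9 heavy atoms (6 carbon, 3 nitrogen; one five-membered aromatic ring with 3 hetero atoms, one six-membered aromatic ring of carbon only) in place of a group of 9 heavy atoms (6 carbon, 1 nitrogen, 2 oxygen; one six-membered aromatic ring of carbon only), on a carbonyl carbon. For the measured compounds named here, no measured step swaps the whole terminal aryl group, so only the step from compound 2 to compound 3 bears on it, and that step stayed within the scatter. The change at this carbonyl carbon has so far moved nothing, and on that basis the expected step of a 1.1-fold lower number from compound 3 to compound 4 (0.04 log units; within the scatter) is small and not beyond the scatter, with no preferred direction. For compound 4 the estimate in this assay is 280 nM, ranging from 110 nM to 750 nM.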

Compound 4, half-maximal inhibitory concentration: 990 nM
Estimate against measurement, compound 4: 3.5-fold (0.55 log units) below, outside the stated range (above it).
By their numbers in this assay, from the lowest: compounds 2, 3 and 1 (each within the scatter of the next, the first and the last beyond it); then compound 4.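

Until now this carbonyl carbon had not separated its groups, as the swap of a 1.8-fold higher number from compound 2 to compound 3 (0.26 log units; within the scatter) stayed within the scatter in this assay. The group with a five-membered aromatic ring holding 3 hetero atoms and a six-membered aromatic ring of carbon only now separates itself from 4-nitrophenyl by a 3.2-fold higher number from compound 3 to compound 4 (0.50 log units; beyond the scatter) and from the methoxycarbonyl-bearing aryl group by a 5.8-fold higher number from compound 2 to compound 4 (0.77 log units; beyond the scatter) so this position does respond to the group it carries, and both single-ring groups give lower numbers than the two-ring group. Nothing available accounts for this step.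

On these data alone, whether the second ring or the hydrogen-bond donor of the entering group goes with the higher number stays open, and a methyl group on that ring's nitrogen or a plain phenyl would bear on this. Also open, as far as these compounds go, is whether the same group gives a similar step on the core of compound 1.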